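This account rests on a few compounds, and the source may have more. Where it says the series, first, only, none or still open, it means among the compounds named here.

Compound 1 `COc1ccc(/C=C/C2(C)C=CC(=O)O2)cc1OC` gives 84100 nM in a functional assay on UACC-62 cells (Homo sapiens) for inhibition, read by sulforhodamine B assay, with a stated time of 48 h; on this read-out lower numbers stand for stronger inhibition of growth and higher numbers for weaker inhibition of growth. Within the data shown here, the only other measured compound, compound 2 `COc1cc(OC)c(OC)cc1/C=C/C1(C)C=CC(=O)O1`, gives 127000 nM, so the two values lie within the scatter of each other and compound 1 cannot be ranked against it. Compound 3 `COc1cc(/C=C/C2(C)C=CC(=O)O2)cc(OC)c1OC` has not yet been measured. It differs from compound 1 by methoxy in place of hydrogen on an aromatic carbon, ortho to a methoxy group and meta to a methoxy group. Among the measured compounds shown here, one measured step bears on this change, a 1.5-fold higher number from compound 1 to compound 2 (0.18 log units; within the scatter), which is the same exchange at a different aromatic carbon. On this single step, no change beyond the scatter is expected in this assay. The expected step is a 1.1-fold higher number from compound 1 to compound 3 (0.05 log units; within the scatter). For compound 3 the estimated value is 95000 nM, with an expected range of 45000 nM to 200000 nM.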

Compound 3, concentration for total growth inhibition: 179000 nM
The estimate for compound 3 lay 1.9-fold (0.28 log units) below the measured number; low and high end bracket the measured number.
By their numbers in this assay, from the lowest: compounds 1, 2 and 3 (each within the scatter of the next, the first and the last beyond it).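

In this assay the exchange of hydrogen for methoxy, on the aromatic carbon ortho to a methoxy group and meta to a methoxy group, gives a 2.1-fold higher number from compound 1 to compound 3 (0.33 log units; beyond the scatter) and so goes with modestly weaker inhibition of growth. Among these compounds, the same exchange at a different aromatic carbon had given only a 1.5-fold higher number from compound 1 to compound 2 (0.18 log units; within the scatter), so this position provides the first step that can be read as a change, though a modest one. Nothing measured on these compounds accounts for the step.

As far as these compounds go, it remains open whether this outcome is particular to methoxy, since a hydroxy group, a fluorine atom or a longer chain such as ethoxy on the same carbon would test that. From the compounds shown here alone, the effect of an amine or a carboxylic acid at this position also remains open.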